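A few compounds are considered here, and "the series" means these few. Any claim that something is new, unique, unknown or untested is made for them only; others in the source may bear on it.

Series notes. Among the measured compounds shown here, compound 2 `Cc1c(C#Cc2ccc(CCC(=O)O)cc2)ccnc1Cl` gives in an in vitro functional assay on 1321-N1 cells for agonist activity at Free fatty acid receptor 1 (Homo sapiens), read by fluorescence, spectrophotometry and calcium flux (a lower number here means that less compound is needed, a higher number that more compound is needed for the effect), a value of 135 nM, the lowest of the three numbers measured so far. Compound 3 `O=C(O)CCc1ccc(C#Cc2ccnc(Cl)c2)cc1` gives 295 nM in this assay; the step of a 2.2-fold higher number from compound 2 to compound 3 (0.34 log units; beyond the scatter) is the smallest gap within the set. Compound 1 `O=C(O)CCc1ccc(C#Cc2ccnc(F)c2)cc1` gives 513 nM in this assay and stands furthest from compound 2.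

Compound 4 `Cc1c(C#Cc2ccc(CCC(=O)O)cc2)ccnc1F` differs from compound 2 by fluoro in place of chloro on an aromatic carbon. The measured step that bears on this change is the same halogen exchange run the other way on the core without the methyl group, a 1.7-fold lower number from compound 1 to compound 3 (0.24 log units; within the scatter). The step of a 2.2-fold higher number from compound 2 to compound 3 (0.34 log units; beyond the scatter) concerns the methyl group alone and does not speak to the halogen exchange directly. Reading the halogen step backwards, the number for compound 4 is expected to change little, if at all, and to stay within the scatter: a 1.7-fold higher number from compound 2 to compound 4 (0.23 log units; within the scatter). The estimate for compound 4 in this assay is 230 nM, with a range of 110 nM to 500 nM.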

Compound 4, half-maximal effective concentration: 120 nM
Estimate against measurement, compound 4: 1.9-fold (0.28 log units) above, within the range that was stated.
By their numbers in this assay, from the lowest: compounds 4 and 2 (each within the scatter of the next); then compounds 3 and 1 (each within the scatter of the next).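

At the position next to the ring nitrogen and ortho to a methyl group, fluoro in place of chloro leaves no readable change in this assay (a 1.1-fold lower number from compound 2 to compound 4 (0.05 log units; within the scatter)). The halogen exchange therefore reads as within the scatter both on the core with the methyl group and on the core without it: the same change on two cores in this assay, a 1.7-fold lower number (0.24 log units; within the scatter) from compound 1 to compound 3 and a 1.1-fold higher number (0.05 log units; within the scatter) from compound 4 to compound 2, 2.0-fold (0.29 log units) apart, within the scatter of two such steps. The methyl group now has a second reading, with fluoro as well as with chloro (a 4.3-fold lower number from compound 1 to compound 4 (0.63 log units; beyond the scatter)), and the two readings agree: the same change on two cores in this assay, a 2.2-fold higher number (0.34 log units; beyond the scatter) from compound 2 to compound 3 and a 4.3-fold higher number (0.63 log units; beyond the scatter) from compound 4 to compound 1, 2.0-fold (0.29 log units) apart, within the scatter of two such steps.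

The compounds shown leave open how a bromo, a methoxy or an amino group in place of the halogen would read. They also leave open whether an ethyl group in place of the methyl group would keep the step that the methyl group gives on both halogen cores.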